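Trimming the pent-1-en-1-yl chain of compound 3

A few compounds are considered here, and "the series" means these few. Any claim that something is new, unique, unknown or untested is made for them only; others in the source may bear on it.

In a functional assay on HCT-116 cells (Homo sapiens) for inhibition, read by MTT assay, with a stated time of 48 h (on this read-out higher numbers stand for weaker inhibition and lower numbers for stronger inhibition), compound 1 (`COc1ccc(CN(C(C)=O)c2cc(OC)c(OC)c(OC)c2)cc1O`) gives 270 nM, compound 2 (`C#CC(=O)N(Cc1ccc(OC)c(O)c1)c1cc(OC)c(OC)c(OC)c1`) gives 310 nM and compound 3 (`CCC/C=C/C(=O)N(Cc1ccc(OC)c(O)c1)c1cc(OC)c(OC)c(OC)c1`) gives 95 nM. Compound 3 has the lowest number of the three, and it is the most potent of this small set: a 2.8-fold lower number from compound 1 to compound 3 (0.45 log units; beyond the scatter) and a 3.3-fold lower number from compound 2 to compound 3 (0.51 log units; beyond the scatter). By contrast, a 1.1-fold higher number from compound 1 to compound 2 (0.06 log units; within the scatter).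

The next compound is compound 4 (`CC/C=C/C(=O)N(Cc1ccc(OC)c(O)c1)c1cc(OC)c(OC)c(OC)c1`), in which pent-1-en-1-yl becomes but-1-en-1-yl: hydrogen in place of methyl on a saturated chain carbon, two bonds along the chain from a double-bonded chain carbon. This is hydrogen in place of methyl on a saturated chain carbon, two bonds along the chain from a double-bonded chain carbon.

For the measured compounds named here, no measured step isolates this change. The nearest evidence is the pair of modest steps above, and both replace the whole pent-1-en-1-yl group with something quite different. Compound 4 stays far closer to compound 3 than either compound 1 or compound 2 does, so only part of a step of that size seems likely in this assay. A small move towards a higher number is expected, probably not beyond the scatter, and the estimated step is a 1.4-fold higher number from compound 3 to compound 4 (0.14 log units; within the scatter). For compound 4 the expected value is 130 nM, with an estimated range of 60 nM to 280 nM.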

Compound 4, half-maximal inhibitory concentration: 63 nM
Compound 4: middle estimate off by 2.1-fold (0.31 log units), on the high side; the measured number falls inside the stated range.
By their numbers in this assay, from the lowest: compounds 4 and 3 (each within the scatter of the next); then compounds 1 and 2 (each within the scatter of the next).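

In this assay the change from pent-1-en-1-yl to but-1-en-1-yl gives a 1.5-fold lower number from compound 3 to compound 4 (0.18 log units; within the scatter) and so shows that this saturated chain carbon, two bonds along the chain from a double-bonded chain carbon, can carry hydrogen in place of methyl without a shift beyond the scatter. The gap to the smaller groups on the carbonyl carbon also remains with the shorter chain: ethynyl to but-1-en-1-yl gives a 4.9-fold lower number from compound 2 to compound 4 (0.69 log units; beyond the scatter) and methyl to but-1-en-1-yl gives a 4.3-fold lower number from compound 1 to compound 4 (0.63 log units; beyond the scatter) in this series, so the full pent-1-en-1-yl length is not required for a step beyond the scatter from either compound. Nothing available here gives a reason for these results.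

The compounds shown leave open how far the chain can be changed in either direction, from a shorter prop-1-en-1-yl group to a longer hex-1-en-1-yl chain. They also leave open whether the double bond itself matters, which a saturated butyl or propyl chain would test, and whether a terminal amine or carboxylic acid on the chain would be accepted in this assay.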